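The compounds below may be only part of what the source reports. "The series", "measured", "known", "first", "only" and "open" are said of these compounds alone.

Of the compounds shown here, two have been measured in a functional assay on HCT-116 cells (Homo sapiens) for cytotoxicity, read by scintillation counting and thymidine incorporation, with a stated time of 72 h (on this read-out higher numbers stand for weaker inhibition and lower numbers for stronger inhibition), and they lie far apart. For the measured compounds named here, compound 1 (`CC=C(c1cc(OC)cc(OC)c1)c1ccc(OC)c(O)c1`) gives 30 nM, the only true number available. Compound 2 (`COc1cc(OC)cc(C(=CCCN(C)C)c2ccc(OC)c(OC)c2)c1`) gives > 10000 nM, which is a limit of the assay and not a number. On these data alone, compound 2 therefore stands at the weak end of what was measured, and how weak it really is remains unknown; the evidence records this as the limit of > 10000 nM in this assay, at which 1 of the 2 values shown sits.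

Compound 3 (`CC=C(c1cc(OC)cc(OC)c1)c1ccc(OC)c(OC)c1`) is reached from compound 2 by a single change: hydrogen in place of (dimethylamino)methyl on a saturated chain carbon bound to a double-bonded chain carbon, (hydrogen in place of (dimethylamino)methyl on a saturated chain carbon bound to a double-bonded chain carbon). Going by the values given here, no measured pair shows what this change does in this assay, so any forecast is uncertain. Among the compounds with values here, the only numerical anchor is compound 1 at 30 nM. A value for compound 3 is expected to fall between that anchor and the limit of compound 2. The expected direction is toward stronger inhibition, with an estimated step of an at least 25-fold lower number from compound 2 to compound 3 (1.39 log units; beyond the scatter). For compound 3 the estimated value is 400 nM, with an expected range of 50 nM to 4000 nM.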

Compound 3, half-maximal inhibitory concentration: 480 nM
For compound 3 the middle estimate is 1.2-fold (0.08 log units) below the measured one, and the stated range covers the measured number.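

In this assay, hydrogen in place of (dimethylamino)methyl on a saturated chain carbon bound to a double-bonded chain carbon gives an at least 20-fold lower number from compound 2 to compound 3 (1.31 log units; beyond the scatter), so this place on the chain now has a direct comparison, and the compound carrying the shorter methyl end retains measurable inhibition. Compound 2 remains a limit of the assay and not a number, so the size of this step is known only as a bound: the limit of > 10000 nM in this assay, at which 1 of the 3 values shown sits. The result also supplies a second single-place comparison: methyl in place of hydrogen on an oxygen on an aromatic ring gives a 16-fold higher number from compound 1 to compound 3 (1.20 log units; beyond the scatter), which shows that this oxygen also matters in this assay, while the chain is unchanged.

The compounds shown leave open whether the contrast at the chain follows from the dimethylamino nitrogen or from the chain length, a question that a plain propyl chain or a chain ending in a hydroxyl group could separate. They also leave open how a chain ending in a morpholine or a carboxylic acid would read, and whether the 2-(dimethylamino)ethyl chain would give the same result on the core of compound 1.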